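A few compounds are considered here, and "the series" means these few. Any claim that something is new, unique, unknown or untested is made for them only; others in the source may bear on it.

Compound 1 `COc1ccc(C23CCC(=O)N2CCCO3)cc1` and compound 2 `O=C1CCC2(c3ccc(Cl)cc3)OCCCN12` share a core and differ in the group on the aromatic ring. In a functional assay on the whole organism with Mus musculus as the target, in the maximal electroshock model (a higher number here means that more compound is needed for the effect, a lower number that less compound is needed), compound 1 gives 93.8 mg/kg and compound 2 gives 58 mg/kg, so compound 2 has the lowest of the two numbers, with compound 1 nearest at a 1.6-fold lower number from compound 1 to compound 2 (0.21 log units; within the scatter). Compound 3 `O=C1CCC2(c3ccc(Cl)c(Cl)c3)OCCCN12` carries a further change: chloro in place of hydrogen on an aromatic carbon. Among the measured compounds shown here, no measured step of this kind exists; the only step, between compound 1 and compound 2, swaps one group for another and lies within the scatter. The step from compound 2 to compound 3 is therefore expected to be a 1.2-fold lower number from compound 2 to compound 3 (0.06 log units; within the scatter), none beyond the scatter. For compound 3 in this assay the expected value is 50 mg/kg, with a range from 25 mg/kg to 100 mg/kg.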

Compound 3, dose for half-maximal effect: 113 mg/kg
Compound 3: the middle estimate sits 2.3-fold (0.35 log units) below what was measured; measured number outside the range, above it.
By their numbers in this assay, from the lowest: compounds 2, 1 and 3 (each within the scatter of the next).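

In this assay chloro in place of hydrogen, on the aromatic carbon ortho to a chloro group and meta to a large group, gives a 1.9-fold higher number from compound 2 to compound 3 (0.29 log units; within the scatter). Among the compounds shown here, this is the first reading at this aromatic carbon, and it shows that a chloro group can be placed there without a step beyond the scatter. Nothing available bears on the reason for this result. On these data alone, whether an amine or a carboxylic acid on this aromatic carbon would produce a step beyond the scatter stays open.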